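The source may hold more compounds than are shown below. What is called first, only, known or untested is meant among the compounds shown, and "the series" means these compounds.

Of the compounds shown here, two have been measured in a functional assay on HepG2 cells (Homo sapiens) for antiproliferative activity, read by CCK-8 assay, with a stated time of 72 h, tested at 2 uM (a higher number here means a stronger effect of the compound at the concentration tested, a lower number a weaker effect), so far. Compound 1 `CCCCn1cnc2c(Nc3cccc(Cl)c3)nc(NCOCc3ccc(/C=C/C(=O)Nc4ccccc4N)cc3)nc21` gives 20.5% there, and compound 2 `CCCCn1cnc2c(Nc3ccccc3)nc(NCOCc3ccc(C(=O)Nc4ccccc4N)cc3)nc21` gives 46.6%. Going by the values given here, compound 2 therefore stands highest of the two numbers, with compound 1 as its only neighbour at a value that lies beyond the scatter below it; the two differ in more than one place, so what separates them cannot be assigned to any single change.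

Compound 3 `CCCCn1cnc2c(Nc3cccc(Cl)c3)nc(NCOCc3ccc(C(=O)Nc4ccccc4N)cc3)nc21` has not yet been measured in this assay. It differs from compound 2 by chloro in place of hydrogen on an aromatic carbon. Among the compounds with values here, with no measured pair isolating this change, the step from compound 2 to compound 3 is hard to predict; a small decrease is expected, one that may stay within the scatter, a number 8.6 percentage points lower from compound 2 to compound 3 (within the scatter). Compound 3 is estimated to give 38% in this assay, within a range from 18% to 58%.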

Compound 3, a percentage reported as inhibition, at one concentration (the size of the read-out at that concentration, not a potency): 30.6%
Compound 3: the middle estimate sits 7.4 percentage points above what was measured; the range from low to high includes it.
By their numbers in this assay, from the lowest: compound 1; then compound 3; then compound 2.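

Going by these compounds alone, compound 3 isolates the (3-chlorophenyl)amino group for the first time: in this assay, moving from anilino to (3-chlorophenyl)amino gives a number 16 percentage points lower from compound 2 to compound 3 (beyond the scatter), so this single chloro in place of hydrogen is enough to lower the read-out. Compound 3 also isolates the other difference, as (2-aminophenyl)carbamoyl in place of 2-((2-aminophenyl)carbamoyl)ethenyl gives a number 10.1 percentage points higher from compound 1 to compound 3 (beyond the scatter), so the gap between compound 1 and compound 2 now resolves into two single changes, each printed as beyond the scatter. Nothing available explains either step.

Whether the lower read-out is particular to chloro stays open, since fluoro, methyl or methoxy at this place are not among the compounds shown. Also open, from the compounds shown here alone, is whether the ethenyl step would hold with plain anilino on the shared core.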